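From isopropyl to oxetan-3-yl on a sulfonyl sulfur

The source may report more compounds than this note shows. Statements on the series, on what has been measured and on what is new or still open speak of the compounds shown alone.

Measured so far in an ADME assay on microsomes from liver (Mus musculus) for metabolic stability, read by LC-MS, with a stated time of 40 min, tested at 0.5 uM; on this read-out lower numbers stand for slow clearance and higher numbers for fast clearance:
compound 1 `CC(C)S(=O)(=O)c1cccc(NC(=O)c2cccnc2N2CCC3(CC2)CC3)c1`: > 399 mL.min-1.g-1
compound 2 `CC(C)(C)NS(=O)(=O)c1cccc(NC(=O)c2ncc(NS(C)(=O)=O)nc2N2CCC3(CC2)CC3)n1`: 64 mL.min-1.g-1

Compound 1 sits at the limit of > 399 mL.min-1.g-1 in this assay, at which 1 of the 2 values shown sits. This is a limit and not a number. Compound 2 gives a true number of 64 mL.min-1.g-1, but it differs from compound 1 in more than one place. Within the data shown here, no pair of measured compounds differing in one place is available as a guide.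

Compound 3 `O=C(Nc1cccc(S(=O)(=O)C2COC2)c1)c1cccnc1N1CCC2(CC1)CC2` has oxetan-3-yl in place of isopropyl on a sulfonyl sulfur. Compound 1 reads > 399 mL.min-1.g-1, which leaves the starting point open, so only a moderate move towards slower clearance is expected, and a reading at the limit remains possible. The expected step is an at least 1.9-fold lower number from compound 1 to compound 3 (0.29 log units; that floor lies within the scatter). For compound 3 the estimated clearance is 200 mL.min-1.g-1, with an expected range from 70 mL.min-1.g-1 to 400 mL.min-1.g-1.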

Compound 3, intrinsic clearance in microsomes: 385 mL.min-1.g-1
Estimate against measurement, compound 3: 1.9-fold (0.28 log units) below; the range from low to high includes it.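

In this assay compound 3 gives a true number, 385 mL.min-1.g-1, so this position now has a measured value with oxetan-3-yl on the sulfonyl sulfur, which compound 1 could not supply. Compound 1 remains a limit of the assay and not a number: the limit of > 399 mL.min-1.g-1 in this assay, at which 1 of the 3 values shown sits. As far as these compounds go, the change therefore reads only as an at least 1.0-fold lower number from compound 1 to compound 3 (0.01 log units; that floor lies within the scatter), so adding the four-membered ring with its oxygen shows no step beyond the usual scatter, and the true size of the step stays unknown.

From the compounds shown here alone, what compound 1 would read without the limit remains open, and with it whether oxetan-3-yl changes clearance at all. Also open, going by these compounds, is how a methyl group or a methoxyethyl chain on the same sulfonyl sulfur would read against the number for compound 3.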